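The source may hold more compounds than are shown below. What is called first, only, known or untested is meant among the compounds shown, and "the series" means these compounds.

Two ureas built on one shared core have been measured in an assay on isolated protein for inhibition of proto-oncogene tyrosine-protein kinase receptor Ret (Homo sapiens), read by 33P incorporation, with stated times of 15 min and 40 min; a higher number here means a weaker inhibitor, a lower number a stronger inhibitor. Compound 1 `COc1cccc(NC(=O)Nc2ccc(Nc3ncnc4c3OCCN4)cc2)c1` carries a 3-methoxyphenyl group on one urea nitrogen; in this assay compound 1 gives 6810 nM. Compound 2 `O=C(Nc1ccc(Nc2ncnc3c2OCCN3)cc1)Nc1cc(Cl)cc(Cl)c1` carries a 3,5-dichlorophenyl group at the same place; in this assay compound 2 gives 865 nM. Going by the values given here, the single change between them gave a 7.9-fold lower number from compound 1 to compound 2 (0.90 log units; beyond the scatter), so compound 2 stands as the lower of the two numbers so far.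

Compound 3 `CC(C)(C)c1cc(NC(=O)Nc2ccc(Nc3ncnc4c3OCCN4)cc2)no1` is unmeasured. It differs from compound 2 by 5-(tert-butyl)-1,2-oxazol-3-yl in place of 3,5-dichlorophenyl on an amide-type nitrogen. Among the compounds with values here, the only measured step, from compound 1 to compound 2, also swapped the group on this urea nitrogen, and it moved the number by a modest amount beyond the scatter; it does not involve a five-membered ring with two hetero atoms, so it shows only that this position can shift the read-out, not in which direction the present change will go.

Compound 3 is therefore expected to stay near compound 2, with a step of a 1.4-fold lower number from compound 2 to compound 3 (0.16 log units; within the scatter), and is estimated at 600 nM, within a range from 120 nM to 3000 nM.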

Compound 3, half-maximal inhibitory concentration: 10 nM
Compound 3: the middle estimate sits 60-fold (1.78 log units) above what was measured; measured number below the stated range.
By their numbers in this assay, from the lowest: compound 3; then compound 2; then compound 1.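

In this assay, the group on this urea nitrogen proves able to move the number much further than the two phenyl compounds suggested: the change to 5-(tert-butyl)-1,2-oxazol-3-yl gives an 87-fold lower number from compound 2 to compound 3 (1.94 log units; beyond the scatter), and the same group gives a 680-fold lower number from compound 1 to compound 3 (2.83 log units; beyond the scatter). Both steps are far larger than a 7.9-fold lower number from compound 1 to compound 2 (0.90 log units; beyond the scatter), so swapping one substituted phenyl for another explored only a small part of what this position can do, while replacing the six-membered carbon ring with a five-membered aromatic ring with 2 hetero atoms brought the number down into a new range. No measurement here bears on why the step is so large.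

The ring and the tert-butyl group entered together, so these compounds cannot show which of them accounts for the drop; a 5-methyl-1,2-oxazol-3-yl group, or a phenyl ring carrying a tert-butyl group, would help separate the two. Also open, going by these compounds, is how this nitrogen behaves with a group lacking an aromatic ring, such as cyclohexyl or a longer alkyl chain.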